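Compound 1 to compound 3: hydrogen for methoxy

A few compounds are considered here, and "the series" means these few. Any claim that something is new, unique, unknown or untested is made for them only; others in the source may bear on it.

Measured in a functional assay on HUVEC cells (Homo sapiens) for inhibition, with stated times of 2 h and 72 h; on this read-out lower numbers stand for stronger inhibition and higher numbers for weaker inhibition:
- compound 1 `COc1cccc(Nc2nn(C)c3cc(Oc4ccnc5cc(OC)c(OC)cc45)ccc23)c1`: > 1000 nM
- compound 2 `COc1ccc(C(=O)Nc2nn(C)c3cc(Oc4ccnc5cc(OC)c(OC)cc45)ccc23)cc1`: > 1000 nM

Compound 1 stands at > 1000 nM, which is a limit and not a number. Compound 2 stands at > 1000 nM, which is likewise a limit. For the measured compounds named here, the series so far therefore amounts to the limit of > 1000 nM in this assay, at which 2 of the 2 values shown sit.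

Compound 3 `COc1cc2nccc(Oc3ccc4c(Nc5ccccc5)nn(C)c4c3)c2cc1OC` keeps the core of compound 1 and has hydrogen in place of methoxy on an aromatic carbon, so that 3-methoxyphenyl becomes phenyl: hydrogen in place of methoxy on an aromatic carbon.

Going by the values given here, the only measured step is a step that the two limits leave unreadable from compound 1 to compound 2. Among the compounds with values here, it replaces the same 3-methoxyphenyl group but gives no size, and no measured step covers the loss of the methoxy alone. The data thus offer no direction for the change. The working expectation rests on compound 1 at > 1000 nM, a limit, and no step beyond the scatter is expected in this assay.

The estimated move is a step that the limit leaves unreadable from compound 1 to compound 3. A report of compound 3 as a limit again is expected to be the likelier outcome. As a number, compound 3 is expected at 1500 nM, with an estimated range of 200 nM to 10000 nM.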

Compound 3, half-maximal inhibitory concentration: > 1000 nM
Compound 3 ended at the assay's limit; the forecaster's own chance of this, stated with the estimate: 60%; the middle value does not contradict the limit.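

Compound 3 gives > 1000 nM in this assay, which is a limit and not a number. The steps from compound 1 and from compound 2 to compound 3 therefore cannot be read, and the series rests on one limit: the limit of > 1000 nM in this assay, at which 3 of the 3 values shown sit.

Left open is what values compound 1, compound 2 and compound 3 have beyond that limit, and whether the differences among their groups matter in this assay.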